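Ethoxy for Methyl on the Carbonyl of Compound 2

The source may hold more compounds than are shown below. What is called first, only, known or untested is meant among the compounds shown, and "the series" means these compounds.

Compound 1, `O=C(CSC(=S)N[C@H]1CCOC1=O)Nc1ccc(Br)cc1`, in a functional assay on SMMC-7721 cells (Homo sapiens) for cytotoxicity, read by MTT assay, with a stated time of 72 h (on this read-out higher numbers stand for weaker inhibition and lower numbers for stronger inhibition), gives 28300 nM. Compound 2, `CC(=O)c1ccc(NC(=O)CSC(=S)N[C@H]2CCOC2=O)cc1`, in this assay reaches only the limit > 128000 nM.

Compound 2 therefore stands at the top end of the numbers shown, the weaker of the two, since the step of an at least 4.5-fold higher number from compound 1 to compound 2 (0.65 log units; beyond the scatter) lies beyond the scatter and its value is one of the values sitting at the limit of > 128000 nM in this assay, at which 1 of the 2 values shown sits. Compound 3, `CCOC(=O)c1ccc(NC(=O)CSC(=S)N[C@H]2CCOC2=O)cc1`, differs from compound 2 by ethoxy in place of methyl on a carbonyl carbon. Among the compounds with values here, the only measured step, an at least 4.5-fold higher number from compound 1 to compound 2 (0.65 log units; beyond the scatter), concerns a change on the aromatic carbon, not on the carbonyl carbon, so it bears on the present change only loosely, and no measured step alters the carbonyl substituent itself. No step beyond the scatter is expected in this assay. Compound 3 is accordingly estimated at 110000 nM, within 30000 nM to 300000 nM. The step of an at least 1.1-fold lower number from compound 2 to compound 3 (0.06 log units; that floor lies within the scatter) is the expected outcome.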

Compound 3, half-maximal inhibitory concentration: 64900 nM
For compound 3 the middle estimate is 1.7-fold (0.23 log units) above the measured one, within the range that was stated.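

In this assay, the carbonyl carbon now carries a measured change, with ethoxy in place of methyl giving an at least 1.9-fold lower number from compound 2 to compound 3 (0.29 log units; that floor lies within the scatter). On these data alone, compound 2 has only a limit and not a number, so this step is a floor and its true size stays unknown: the limit of > 128000 nM in this assay, at which 1 of the 3 values shown sits. Against the bromo group of compound 1, ethoxycarbonyl on the aromatic carbon gives a 2.3-fold higher number from compound 1 to compound 3 (0.36 log units; beyond the scatter), so this group, like acetyl, leaves the number higher than bromo does, though here the modest step is read from two actual numbers.

The compounds shown leave open whether the real gap between the methyl and ethoxy forms lies beyond the scatter, and how an amine or a longer alkoxy chain on the same carbonyl carbon would read in this assay. They also leave open how a chloro group on the aromatic carbon would compare with bromo.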